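Moving the Nitro Group Along the Ring

This account rests on a few compounds, and the source may have more. Where it says the series, first, only, none or still open, it means among the compounds named here.

Measured so far:
compound 1 `N#Cc1c(-c2ccccc2O)c(C#N)c(=O)n(/N=C/c2cn(-c3ccccc3)nc2-c2ccccc2)c1N` — in an ADME assay on HeLa cells (Homo sapiens) for cytotoxicity, read by MTT assay (a higher number here means a weaker inhibitor, a lower number a stronger inhibitor), compound 1 gives > 200 ug/mL, which is a limit of the assay and not a number.
compound 2 `N#Cc1c(-c2ccc(F)cc2)c(C#N)c(=O)n(/N=C/c2cn(-c3ccccc3)nc2-c2ccccc2)c1N` — compound 2 gives > 200 ug/mL, again a limit rather than a number.
compound 3 `N#Cc1c(-c2ccccc2[N+](=O)[O-])c(C#N)c(=O)n(/N=C/c2cn(-c3ccccc3)nc2-c2ccccc2)c1N` — compound 3 gives > 200 ug/mL, also a limit.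

Among the measured compounds shown here, compound 1 therefore stands only at a limit, and the two further values shown are limits as well, so no compound here can be set apart from another. The new compound 4 `N#Cc1c(-c2cccc([N+](=O)[O-])c2)c(C#N)c(=O)n(/N=C/c2cn(-c3ccccc3)nc2-c2ccccc2)c1N` is made from compound 1 by the change (3-nitrophenyl in place of 2-hydroxyphenyl on an aromatic carbon). For the measured compounds named here, the steps that bear on this change all start or end at a limit: a step that the two limits leave unreadable from compound 1 to compound 2, a step that the two limits leave unreadable from compound 1 to compound 3 and a step that the two limits leave unreadable from compound 2 to compound 3 all leave their size unreadable. Going by the values given here, the one piece of evidence is the limit of > 200 ug/mL in this assay, at which 3 of the 3 values shown sit, which shows every value so far at that same limit. Nothing therefore points to a readable step in this assay in either direction, and compound 4 is expected to sit at the limit too. Compound 4 is estimated at 250 ug/mL, with a range from 150 ug/mL to 450 ug/mL. That estimate would mean a step that the limit leaves unreadable from compound 1 to compound 4, expected to stay within the scatter.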

Compound 4, half-maximal inhibitory concentration: > 200 ug/mL
Compound 4: a limit, no number; the forecaster's own chance of this, stated with the estimate: 90%; the middle value does not contradict the limit.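

In this assay compound 4 gives > 200 ug/mL, which is a limit and not a number. Its steps from compound 1, compound 2 and compound 3 cannot be read, so none of these four compounds can be set apart: the limit of > 200 ug/mL in this assay, at which 4 of the 4 values shown sit. The compounds shown leave open whether any change of this group on the shared core would give a readable value in this assay.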